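The compounds below may be only part of what the source reports. "The series", "measured", "known", "first", "only" and "open" are said of these compounds alone.

Three compounds share one core that carries a sulfonamide. Compound 1 `CC1(C)C=C(n2ccccc2=O)c2cc(S(N)(=O)=O)ccc2O1` has an unsubstituted sulfonamide nitrogen, compound 2 `CNS(=O)(=O)c1ccc2c(c1)C(n1ccccc1=O)=CC(C)(C)O2` a methyl on it and compound 3 `CCNS(=O)(=O)c1ccc2c(c1)C(n1ccccc1=O)=CC(C)(C)O2` an ethyl. In a functional assay on the whole organism (trachea) with Rattus norvegicus as the target (on this read-out higher numbers stand for larger maximal responses and lower numbers for smaller maximal responses), compound 1 gives 92.1%, compound 2 gives 83% and compound 3 gives 87%, the second highest of the three. Every step among them lies within the scatter: a number 9.1 percentage points lower from compound 1 to compound 2 (within the scatter), a number 5.1 percentage points lower from compound 1 to compound 3 (within the scatter) and a number 4 percentage points higher from compound 2 to compound 3 (within the scatter). Compound 4 `CC(C)NS(=O)(=O)c1ccc2c(c1)C(n1ccccc1=O)=CC(C)(C)O2` differs from compound 3 by methyl in place of hydrogen on a saturated chain carbon bound to a saturated chain carbon and a sulfonamide nitrogen. Among the measured compounds shown here, the only comparable precedent is the earlier addition of a methyl on the chain carbon bound to the sulfonamide nitrogen, which changed nothing beyond the scatter, so no step beyond the scatter is expected here, no change at the digits printed from compound 3 to compound 4 (within the scatter). Compound 4 is estimated to reach 87%, with a range from 77% to 96%.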

Compound 4, largest response reached (Emax), in percent of the reference or control that the assay uses: 94.8%
For compound 4 the middle estimate is 7.8 percentage points below the measured one; low and high end bracket the measured number.
By their numbers in this assay, from the lowest: compounds 2, 3, 1 and 4 (each within the scatter of the next, the first and the last beyond it).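

In this assay, the methyl added to the ethyl chain gives a number 7.8 percentage points higher from compound 3 to compound 4 (within the scatter), and isopropyl in place of hydrogen on the sulfonamide nitrogen gives a number 2.7 percentage points higher from compound 1 to compound 4 (within the scatter). Isopropyl in place of methyl on that nitrogen gives a number 11.8 percentage points higher from compound 2 to compound 4 (beyond the scatter), the first step in this set to pass the scatter, and only a modest one. The group on the sulfonamide nitrogen thus separates just this one pair among the four compounds. Nothing available explains that step. As far as these compounds go, whether a tert-butyl, a cyclopropyl or a longer chain on that nitrogen would keep the response in the same range remains open.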